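Homologating the triazole ester side chain in compound 1

A few compounds are considered here, and "the series" means these few. Any claim that something is new, unique, unknown or untested is made for them only; others in the source may bear on it.

Compound 1 `CCOC(=O)Cn1cc(CNC(=O)c2cnc(Nc3ccc(C#N)cc3)cc2Oc2c(C)cc(C)cc2C)nn1` gives 9530 nM in an ADME assay on MT4 cells (Homo sapiens) for cytotoxicity, read by MTT assay, with a stated time of 5 days (on this read-out lower numbers stand for higher toxicity in this test and higher numbers for lower toxicity in this test), the lowest of the three measured numbers. Compound 2 `CC(=O)Cn1cc(CNC(=O)c2cnc(Nc3ccc(C#N)cc3)cc2Oc2c(C)cc(C)cc2C)nn1` gives 19400 nM and compound 3 `Cc1cc(C)c(Oc2cc(Nc3ccc(C#N)cc3)ncc2C(=O)NCc2cn(CCC#N)nn2)c(C)c1` gives 40200 nM. Compound 4 `CCOC(=O)CCn1cc(CNC(=O)c2cnc(Nc3ccc(C#N)cc3)cc2Oc2c(C)cc(C)cc2C)nn1` differs from compound 1 by (ethoxycarbonyl)methyl in place of ethoxycarbonyl on a saturated chain carbon bound to an aromatic nitrogen. For the measured compounds named here, no measured step is of this kind, but every change at this position moved the number up from compound 1: a 2.0-fold higher number from compound 1 to compound 2 (0.31 log units; beyond the scatter) and a 4.2-fold higher number from compound 1 to compound 3 (0.63 log units; beyond the scatter), with a 2.1-fold higher number from compound 2 to compound 3 (0.32 log units; beyond the scatter) between them. Since the ester group itself is kept here, a small step upward or none beyond the scatter is expected, so compound 4 is estimated at 12000 nM (range 6000 nM to 25000 nM), which would mean a 1.3-fold higher number from compound 1 to compound 4 (0.10 log units; within the scatter).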

Compound 4, half-maximal cytotoxic concentration: 21500 nM
The estimate for compound 4 lay 1.8-fold (0.25 log units) below the measured number, within the range that was stated.
By their numbers in this assay, from the lowest: compound 1; then compounds 2, 4 and 3 (each within the scatter of the next, the first and the last beyond it).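

Lengthening the side chain to 2-(ethoxycarbonyl)ethyl gave a 2.3-fold higher number from compound 1 to compound 4 (0.35 log units; beyond the scatter) in this assay even though the ester group stays, so at this position the number can move without replacing the ester. With a 1.1-fold higher number from compound 2 to compound 4 (0.04 log units; within the scatter) and a 1.9-fold lower number from compound 3 to compound 4 (0.27 log units; within the scatter) both printed as within the scatter, the ester of compound 4 stands level with the side chains of compound 2 and compound 3 in this test. Nothing available here bears on why the longer chain shifts the number. The compounds shown leave open whether a carboxylic acid in place of the ester, or a longer chain still bearing the ester, would give a number like that of compound 4.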